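This account rests on a few compounds, and the source may have more. Where it says the series, first, only, none or still open, it means among the compounds named here.

In an assay on CHO cells for displacement of a labelled ligand from adenosine receptor A3 (Homo sapiens), read by scintillation counting, with a stated time of 120 min (on this read-out higher numbers stand for weaker inhibition and lower numbers for stronger inhibition), three compounds built on the same core have been measured. Among the measured compounds shown here, compound 1 `Cc1ccc(-c2nc3c(=O)[nH]c(C)nc3s2)cc1` gives 33 nM, and compound 2 `Cc1nc2sc(-c3ccc(F)cc3)nc2c(=O)[nH]1` gives 107 nM, so that the only single-point step measured so far, a 3.2-fold higher number from compound 1 to compound 2 (0.51 log units; beyond the scatter), is a modest loss of inhibition. Compound 3 `Cc1nc2sc(-c3cccs3)nc2c(=O)[nH]1` gives 248 nM, the highest number of the three and therefore the weakest inhibition seen; its number lies beyond the scatter above compound 2 and further still above compound 1.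

Compound 4 `Cc1nc2sc(-n3cccc3)nc2c(=O)[nH]1` differs from compound 3 in one place: 1H-pyrrol-1-yl in place of thiophen-2-yl on an aromatic carbon. For the measured compounds named here, no measured step covers an exchange of one five-membered ring for another; the step from compound 1 to compound 2 concerns a different ring and bears on this change only as a sign that single-group changes here have shifted the number by moderate amounts. Going by the values given here, with no direct precedent, the expectation for compound 4 is a small shift, a 1.6-fold higher number from compound 3 to compound 4 (0.21 log units; within the scatter), and an estimated value of 400 nM, within a range from 120 nM to 1300 nM.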

Compound 4, inhibition constant: 227 nM
Beside the measured number, compound 4's estimate is 1.8-fold (0.25 log units) above it; the measured number falls inside the stated range.
By their numbers in this assay, from the lowest: compound 1; then compound 2; then compounds 4 and 3 (each within the scatter of the next).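

Among the compounds shown here, the step of a 1.1-fold lower number from compound 3 to compound 4 (0.04 log units; within the scatter) in this assay is the first measured exchange of a whole ring at this position, on the aromatic carbon next to the ring nitrogen and next to the ring sulfur; the earlier step changed only a group on the attached ring. It lies within the scatter, so this assay does not separate thiophen-2-yl from 1H-pyrrol-1-yl, even though one ring holds sulfur and the other nitrogen and they are attached through different ring atoms. No measurement here accounts for this result.

From the compounds shown here alone, it remains open whether another aromatic ring, such as furan-2-yl or pyridin-3-yl, would read the same at this position. A non-aromatic group, such as morpholine or a simple amine, might also shift the number further than either five-membered ring.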